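This account rests on a few compounds, and the source may have more. Where it says the series, first, only, none or still open, it means among the compounds named here.

Measured compounds:
compound 1, `Cc1ccccc1N1CCN(C[C@H](C)Nc2nc(C(F)(F)F)nc3ccccc23)CC1`, 730 nM
compound 2, `Cc1ccc(S(=O)(=O)N2CCN(C[C@H](C)Nc3ncnc4c(C)csc34)CC2)cc1`, 170 nM
compound 3, `COc1ccccc1N1CCN(C[C@H](C)Nc2nc(C3CC3)nc3ccccc23)CC1`, 3200 nM

All three numbers come from a functional assay on RH7777 cells for antagonist activity at lysophosphatidic acid receptor 2 (Homo sapiens), read by calcium flux; a higher number here means a weaker inhibitor, a lower number a stronger inhibitor. Compound 2 stands lowest of the three: the gap from compound 2 up to compound 1 lies beyond the usual scatter, and the gap up to compound 3 is wider still, so compound 2 is the strongest inhibitor among the measured compounds. Compound 1 and compound 3 share a core that differs from that of compound 2, and their values are read simply as they stand.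

Compound 4, `Cc1csc2c(N[C@@H](C)CN3CCN(S(=O)(=O)Cc4ccccc4)CC3)ncnc12`, keeps the core of compound 2 and differs from it in one place: benzyl in place of 4-methylphenyl on a sulfonyl sulfur. For the measured compounds named here, no pair of measured compounds shows this change, so there is no measured step to lean on. The group that leaves and the group that enters are counted alike, and the change sits on the sulfonyl sulfur at the far end of the molecule from the core. The expectation for this assay is therefore a step of small size from compound 2 to compound 4, leaning toward a weaker inhibitor but possibly none beyond the scatter, expected as a 1.6-fold higher number from compound 2 to compound 4 (0.22 log units; within the scatter). Compound 4 is estimated at 280 nM in this assay, with a range from 90 nM to 900 nM.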

Compound 4, half-maximal inhibitory concentration: 1860 nM
Compound 4: the middle estimate sits 6.6-fold (0.82 log units) below what was measured, outside the stated range (above it).
By their numbers in this assay, from the lowest: compound 2; then compound 1; then compounds 4 and 3 (each within the scatter of the next).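

The swap of 4-methylphenyl for benzyl on the sulfonyl sulfur gives an 11-fold higher number from compound 2 to compound 4 (1.04 log units; beyond the scatter) in this assay, a large step, even though the two groups hold the same atoms, joined differently. For the compounds shown here, the earlier compounds included no pair that differed in one place, so this is the first sign that the group on the sulfonyl sulfur matters, and that the way its atoms are joined can matter even when the counts for the leaving and entering groups are identical. No measured evidence accounts for the size of this step.

The compounds shown leave open whether the weaker inhibition of compound 4 goes with the added link between sulfur and ring or with the loss of the methyl on the ring, as benzyl changes both at once and a plain phenyl on the sulfonyl sulfur would separate the two. Also open, as far as these compounds go, is how a longer chain such as phenethyl, or an amine or a carboxylic acid on the aromatic ring, would read in this assay.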